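Selenocyanate in place of aminoethoxy on the shared core

The compounds below may be only part of what the source reports. "The series", "measured", "known", "first", "only" and "open" are said of these compounds alone.

Compound 1 `COc1ccc(N(C)c2nc(C)nc3ccccc23)cc1OCCN` gives 198 nM in a functional assay on HCT-116 cells (Homo sapiens) for inhibition, read by MTT assay, with a stated time of 48 h (on this read-out higher numbers stand for weaker inhibition and lower numbers for stronger inhibition), the highest of the two numbers recorded so far. Among the compounds with values here, compound 2 `C[Se]c1ccc(N(C)c2nc(C)nc3ccccc23)cc1C` gives 3 nM in this assay; the two values lie far apart, but the structures differ in more than one place, so no single step is drawn from the pair. Compound 3 `COc1ccc(N(C)c2nc(C)nc3ccccc23)cc1[Se]C#N` has not been measured. It differs from compound 1 in one place: a group of 3 heavy atoms (1 carbon, 1 nitrogen, 1 selenium; no ring) in place of a group of 4 heavy atoms (2 carbon, 1 nitrogen, 1 oxygen; no ring), on an aromatic carbon. Within the data shown here, no measured step of this kind is available, so the size of the move is open. Among the measured compounds shown here, the expected step of a 5.0-fold lower number from compound 1 to compound 3 (0.69 log units; beyond the scatter) is toward a lower number, beyond the scatter, an expectation leaning on compound 2 with its 3 nM as the only selenium-bearing member with a value. For compound 3 the estimate in this assay is 40 nM, within a range from 8 nM to 200 nM.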

Compound 3, half-maximal inhibitory concentration: 34 nM
Estimate against measurement, compound 3: 1.2-fold (0.07 log units) above; the measured number falls inside the stated range.
By their numbers in this assay, from the lowest: compound 2; then compound 3; then compound 1.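

At the aromatic carbon ortho to a methoxy group, exchanging 2-aminoethoxy for selenocyanate in this assay gives a 5.8-fold lower number from compound 1 to compound 3 (0.77 log units; beyond the scatter) as a modest gain. In this one pair, the position accepts a selenium-bearing group with 0 hydrogen-bond donors in place of a chain with 1, so that donor is not required to reach the lower number on the shared core. No measurement is available that bears on the reason for this step.

This single pair does not separate the contribution of selenium from that of the nitrile, and a thiocyanate or a plain nitrile at this carbon would address that directly. Also open, from the compounds shown here alone, is how a longer aminoalkoxy chain or a carboxylic acid would read at this position.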